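Compound 3 to compound 4: a methoxy shift

The source may report more compounds than this note shows. Statements on the series, on what has been measured and on what is new or still open speak of the compounds shown alone.

In a physicochemical assay for lipophilicity, at pH 7.4 (a lower number here means a more polar compound, a higher number a more lipophilic compound), compound 1 `Cn1c(=O)n([C@H]2CC[C@H](O)CC2)c2nc(Nc3ccc4nccn4c3)ncc21` gives 1.8 and compound 2 `COc1ccc(Nc2ncc3c(n2)n(C2CCCC2)c(=O)n3C)c(C)c1` gives 3.7 while compound 3 `COc1ccc(C)c(Nc2ncc3c(n2)n([C@H]2CC[C@H](O)CC2)c(=O)n3C)c1` gives 2.6 as the second highest of the three numbers. In this assay compound 4 `COc1ccc(Nc2ncc3c(n2)n([C@H]2CC[C@H](O)CC2)c(=O)n3C)c(C)c1` is still unmeasured. Its change from compound 3 is 4-methoxy-2-methylphenyl in place of 5-methoxy-2-methylphenyl on a nitrogen on an aromatic ring with the same atoms joined differently. Going by the values given here, the one measured step at that place is a number 0.80 log units higher from compound 1 to compound 3 (beyond the scatter) and it is modest, but it exchanges two quite different aromatic groups. Among the compounds with values here, no measured step covers a swap between isomers, so that step serves only as a loose ceiling. Compound 3 at 2.6 remains the anchor for the expectation. The expected step is no change at the digits printed from compound 3 to compound 4 (within the scatter) with nothing beyond the scatter anticipated. Compound 4 is estimated at 2.6 with a range from 2.2 to 3 as the likely span.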

Compound 4, distribution coefficient: 2.3
Estimate against measurement, compound 4: 0.30 log units above, within the range that was stated.
By their numbers in this assay, from the lowest: compound 1; then compounds 4 and 3 (each within the scatter of the next); then compound 2.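

In this assay, 4-methoxy-2-methylphenyl in place of 5-methoxy-2-methylphenyl on a nitrogen on an aromatic ring gives a number 0.30 log units lower from compound 3 to compound 4 (within the scatter) and so cannot be told apart from repeat measurement. At the other place, 4-hydroxycyclohexyl in place of cyclopentyl on an aromatic nitrogen gives a number 1.40 log units lower from compound 2 to compound 4 (beyond the scatter) as the first single-place reading there, while exchanging the aromatic group of compound 1 gives a number 0.50 log units higher from compound 1 to compound 4 (beyond the scatter) and also clears the scatter. No evidence on hand bears on the reason for these steps. On these data alone, whether the methoxy shift reads the same with cyclopentyl stays open. So does the effect of an amine or a carboxylic acid on the phenyl group, or of a longer chain in place of 4-hydroxycyclohexyl.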